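One Ring Swapped on a Sulfur: Expected Cell Effect

The source may hold more compounds than are shown below. What is called first, only, known or untested is meant among the compounds shown, and "the series" means these compounds.

Of the compounds shown here, two of a shared core have been tested so far. Compound 1 `COc1ccc(-c2cs/c(=N/NC(=O)CSc3ncccn3)n2-c2ccccc2)cc1` and compound 2 `Cc1ccc(-c2cs/c(=N/NC(=O)CSc3ncccn3)n2-c2ccccc2)cc1` differ only in a methyl in place of a methoxy on an aromatic carbon. In a functional assay on C6 cells (Rattus norvegicus) for cytotoxicity, read by MTT assay, with a stated time of 24 h, tested at 25 ug/mL (a lower number here means a stronger effect, a higher number a weaker effect of the compound at the concentration tested), compound 1 gives 74% and compound 2 gives 82.7%. The step of a number 8.7 percentage points higher from compound 1 to compound 2 (within the scatter) is small, so compound 2 and compound 1 cannot be told apart on this assay, and compound 2 stands simply as one of two values that lie within the scatter of each other.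

Compound 3 `Cc1ccc(-c2cs/c(=N/NC(=O)CSc3nnnn3C)n2-c2ccccc2)cc1` is the next member. Its difference from compound 2 is 1-methyl-1H-tetrazol-5-yl in place of pyrimidin-2-yl on a sulfur. Within the data shown here, this change sits at a different place from the one measured step: the methyl-for-methoxy exchange touches an aromatic carbon, whereas here a whole ring on a sulfur is replaced. Among the measured compounds shown here, no measured step therefore bears on the change, and there is no basis in the two values to expect a move in this assay beyond the scatter in either direction.

The estimate for compound 3 in this assay is therefore 80%, within a range from 60% to 95%, which corresponds to an expected step of a number 2.7 percentage points lower from compound 2 to compound 3 (within the scatter).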

Compound 3, a percentage reported as activity, at one concentration (the size of the read-out at that concentration, not a potency): 60.7%
For compound 3 the middle estimate is 19.3 percentage points above the measured one, within the range that was stated.
By their numbers in this assay, from the lowest: compound 3; then compounds 1 and 2 (each within the scatter of the next).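

Among these compounds, the group on the sulfur matters in this assay: the step of a number 22 percentage points lower from compound 2 to compound 3 (beyond the scatter) lies beyond the scatter, whereas the one earlier step, made on an aromatic carbon, stayed within it. A lower number here means a stronger effect, so at the concentration tested 1-methyl-1H-tetrazol-5-yl on this sulfur does more than pyrimidin-2-yl, even though the two groups have the same count of heavy atoms and differ in ring size, in their number of nitrogens and in their hydrogen-bond acceptors. No evidence is at hand on the cause of this step, and which of these differences counts remains unknown.

The compounds shown leave open whether the methyl of 1-methyl-1H-tetrazol-5-yl has a share in the step, and whether methoxy in place of methyl on the aromatic carbon would give the same result with this group on the sulfur. They also leave open how a phenyl ring, an imidazole ring or a plain ethyl chain on this sulfur would read in this assay when set beside these values.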